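The compounds below may be only part of what the source reports. "The series", "measured", "known", "first", "only" and "open" are said of these compounds alone.

Among the three measured compounds, compound 2 `CCC(CC)S(=O)(=O)c1ccc(S(=O)(=O)N2CCC[C@@H](C(=O)N3CCN(c4nc(C(C)C)no4)CC3)C2)cc1` has the lowest number in a functional assay on BXPC-3 cells (Homo sapiens) for inhibition, read by MTT assay, with a stated time of 7 days (a higher number here means a weaker inhibitor, a lower number a stronger inhibitor), giving 120 nM. Compound 1 `CCN(CC)S(=O)(=O)c1ccc(S(=O)(=O)N2CCC[C@@H](C(=O)N[C@@H]3CCN(C(=O)OC(C)(C)C)C3)C2)cc1` gives 400 nM in this assay, and compound 3 `CCOC(=O)C12CC(CN(S(=O)(=O)c3ccc(S(=O)(=O)N(CC)CC)cc3)C1)C2` gives 1200 nM; both gaps from compound 2 lie beyond the usual scatter. Compound 4 `CCNS(=O)(=O)c1ccc(S(=O)(=O)N2CCC[C@@H](C(=O)N3CCN(c4nc(C(C)C)no4)CC3)C2)cc1` has not yet been measured. It differs from compound 2 at a single position: ethylamino in place of pentan-3-yl on a sulfonyl sulfur. Among the measured compounds shown here, no measured pair shows this same change, so the direction of the step rests on judgement alone. The step expected a 2.5-fold higher number from compound 2 to compound 4 (0.40 log units; beyond the scatter) is a modest weakening, close to the edge of the scatter. Compound 4 is therefore estimated to give 300 nM, with a likely range from 120 nM to 800 nM.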

Compound 4, half-maximal inhibitory concentration: 6900 nM
Compound 4: middle estimate off by 23-fold (1.36 log units), on the low side; measured number above the stated range.
By their numbers in this assay, from the lowest: compound 2; then compound 1; then compound 3; then compound 4.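

Swapping pentan-3-yl for ethylamino on a sulfonyl sulfur, with the rest of the molecule unchanged, gives a 58-fold higher number from compound 2 to compound 4 (1.76 log units; beyond the scatter) in this assay, so this position is highly sensitive to this change. The earlier compounds shown here offered no such single-change pair. Nothing available explains the size of this step.

Still open, as far as these compounds go, is whether the nitrogen, its hydrogen or the smaller chain drives the loss. A pentan-3-ylamino group or an ethyl group on the same sulfur would help separate these.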